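A few compounds are considered here, and "the series" means these few. Any claim that something is new, unique, unknown or untested is made for them only; others in the source may bear on it.

Measured in a functional assay on A-375 cells (Homo sapiens) for cytotoxicity, read by MTT assay; on this read-out lower numbers stand for stronger inhibition and higher numbers for weaker inhibition:
- compound 1 `CCC(=O)Oc1cc(/C=C/C(=O)c2ccc(OC)c3c2OC(C)(C)C=C3)ccc1OC`: 240 nM
- compound 2 `CCCCC(=O)Oc1cc(/C=C/C(=O)c2ccc(OC)c3c2OC(C)(C)C=C3)ccc1OC`: 220 nM
- compound 3 `COc1ccc(/C=C/C(=O)Oc2cc(/C=C/C(=O)c3ccc(OC)c4c3OC(C)(C)C=C4)ccc2OC)cc1`: 2630 nM

Compound 3 has the highest of these three numbers, which makes it the weakest inhibitor of the set. The next compound, compound 4 `COc1ccc(/C=C/C(=O)c2ccc(OC)c3c2OC(C)(C)C=C3)cc1OS(=O)(=O)c1ccc(C)cc1`, keeps the shared core and changes only the group on the oxygen: (4-methylphenyl)sulfonyl in place of (2-(4-methoxyphenyl)ethenyl)carbonyl on an oxygen on an aromatic ring.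

Going by the values given here, three measured steps bear on this change. Lengthening the saturated chain made no real difference: a 1.1-fold lower number from compound 1 to compound 2 (0.04 log units; within the scatter). Replacing a chain with the 2-(4-methoxyphenyl)ethenyl group made a large difference: an 11-fold higher number from compound 1 to compound 3 (1.04 log units; beyond the scatter), and a 12-fold higher number from compound 2 to compound 3 (1.08 log units; beyond the scatter). Among the compounds with values here, the read-out therefore responds strongly to what is attached at this oxygen, but none of the measured compounds carries a sulfonyl group, so no step tests the new group directly.

The entering group, like the one it replaces, holds an aromatic ring, so compound 4 looks closer to compound 3 than to the two chain compounds. Yet it loses the group found only in compound 3 at 2630 nM, so a moderate drop in the number is expected, not a full return to the chain compounds. The expected change is a 2.6-fold lower number from compound 3 to compound 4 (0.42 log units; beyond the scatter). For compound 4 the estimate is 1000 nM. The expected range runs from 280 nM to 3500 nM.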

Compound 4, half-maximal inhibitory concentration: 2400 nM
Beside the measured number, compound 4's estimate is 2.4-fold (0.38 log units) below it, and the stated range covers the measured number.
By their numbers in this assay, from the lowest: compounds 2 and 1 (each within the scatter of the next); then compounds 4 and 3 (each within the scatter of the next).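

In this assay the exchange of (2-(4-methoxyphenyl)ethenyl)carbonyl for (4-methylphenyl)sulfonyl on this oxygen gives a 1.1-fold lower number from compound 3 to compound 4 (0.04 log units; within the scatter) and so leaves the two numbers within the scatter of each other. Going by these compounds alone, the two saturated chains stand well apart from the sulfonyl compound, with an 11-fold higher number from compound 2 to compound 4 (1.04 log units; beyond the scatter) and also a 10-fold higher number from compound 1 to compound 4 (1.00 log units; beyond the scatter) so the high number is no longer tied to the one group found in compound 3. Across these four compounds, both groups that hold an aromatic ring give higher numbers than both saturated chains, and no compound goes against this, although nothing available explains the gap.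

On these data alone, what stays open is whether the aromatic ring itself matters or the rest of the group does: a methylsulfonyl group or a plain benzoyl group on the same oxygen would help to separate the ring from the link that holds it. The compounds shown also leave open how the number would respond to an amine or a carboxylic acid carried on the entering ring.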